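Methylating the ring nitrogen of compound 3

A few compounds are considered here, and "the series" means these few. Any claim that something is new, unique, unknown or untested is made for them only; others in the source may bear on it.

Going by the values given here, compound 3, `C[C@@H]1CN(c2cccc3c2C[C@H](CN(C)[C@H]2CCCc4cccnc42)NC3)C[C@H](C)N1`, stands at the top of the numbers so far. In an ADME assay on microsomes from liver (Homo sapiens) for metabolic stability, read by LC-MS, with a stated time of 10 min (a lower number here means that less of the compound is left, a higher number that more of the compound is left), compound 3 gives 100%, level with compound 1, `CCCN(C[C@H]1Cc2c(cccc2N2CCNCC2)CN1)[C@H]1CCCc2cccnc21`, which in this assay gives 100%; together these two are the highest of the three measured. Among the compounds with values here, compound 2, `c1cnc2c(c1)CCC[C@@H]2N(CC1CC1)C[C@H]1Cc2c(cccc2N2CCNCC2)CN1`, gives 82.1% in this assay, and the only measured step in the set, a number 17.9 percentage points lower from compound 1 to compound 2 (beyond the scatter), is a modest loss in the compound remaining.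

Compound 4, `C[C@@H]1CN(c2cccc3c2C[C@H](CN(C)[C@H]2CCCc4cccnc42)NC3)C[C@H](C)N1C`, differs from compound 3 in one place: methyl in place of hydrogen on an amine nitrogen in a ring. Put another way, the 3,5-dimethylpiperazin-1-yl of compound 3 becomes 3,4,5-trimethylpiperazin-1-yl in compound 4.

Within the data shown here, no measured step touches this ring nitrogen. Among the measured compounds shown here, the closest precedent is the small alkyl change of a number 17.9 percentage points lower from compound 1 to compound 2 (beyond the scatter), which cost a modest amount, but it sits on a chain carbon rather than on a ring nitrogen, so it bears on the present step only loosely. With compound 3 already at the ceiling of this assay, the expected step of a number 5 percentage points lower from compound 3 to compound 4 (within the scatter) is small, downward if anything, and likely within the scatter. Compound 4 is therefore estimated at 95% in this assay, with a range from 80% to 100%.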

Compound 4, percent of the compound remaining: 24.6%
For compound 4 the middle estimate is 70.4 percentage points above the measured one; the measured number lies below the stated range.
By their numbers in this assay, from the lowest: compound 4; then compound 2; then compounds 1 and 3 (each within the scatter of the next).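

In this assay the ring nitrogen of the 3,5-dimethylpiperazin-1-yl group turns out to be a sensitive position, as the change to 3,4,5-trimethylpiperazin-1-yl gives a number 75.4 percentage points lower from compound 3 to compound 4 (beyond the scatter) and this large step comes from a single added carbon. Going by these compounds alone, the only earlier step (a number 17.9 percentage points lower from compound 1 to compound 2 (beyond the scatter)) was modest and sat on a saturated chain carbon bound to an amine nitrogen, so it gave no sign that a change of one methyl on the amine nitrogen in a ring could take a compound from the top of the set to the bottom. Nothing available bears on why this methyl has so large an effect.

The compounds shown do not separate the methyl itself from its place, next to two ring atoms that each bear a methyl group, as no pair tests the same change on a piperazine without those two methyl groups. On these data alone, whether an ethyl group, a longer chain or an acetyl group on this nitrogen would give a similar number also remains open.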